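From Compound 3 to Compound 4: Expected Microsomal Inhibition

The compounds below may be only part of what the source reports. "The series", "measured", "known", "first", "only" and "open" are said of these compounds alone.

Compound 1 `Cn1c(NN)nc(-c2cccc(O)c2O)c(C#N)c1=O` — 31 ug/mL
Compound 2 `CSc1nc(-c2ccco2)c(C#N)c(=O)n1C` — 90 ug/mL
Compound 3 `CCOC(=O)c1cnn(-c2nc(-c3ccc(Cl)cc3)c(C#N)c(=O)n2C)c1N` — 88 ug/mL

These three compounds were measured in a functional assay on microsomes for inhibition, with a stated time of 1 h; a lower number here means a stronger inhibitor, a higher number a weaker inhibitor. Compound 3 gives the second highest of the three numbers; it lies within the scatter of compound 2, while compound 1 shows a lower number that lies beyond the scatter from compound 3. Compound 4 `CCOC(=O)c1cnn(-c2nc(-c3cccs3)c(C#N)c(=O)n2C)c1N` is not yet measured. The change from compound 3 is thiophen-2-yl in place of 4-chlorophenyl on an aromatic carbon. For the measured compounds named here, no measured pair shares this change, so the expectation rests on compound 3 alone. The step is expected to be small, a 1.1-fold lower number from compound 3 to compound 4 (0.04 log units; within the scatter), none beyond the scatter in this assay. Compound 4 is therefore estimated at 80 ug/mL, with a range from 40 ug/mL to 160 ug/mL.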

Compound 4, half-maximal inhibitory concentration: 97 ug/mL
Beside the measured number, compound 4's estimate is 1.2-fold (0.08 log units) below it, and the stated range covers the measured number.
By their numbers in this assay, from the lowest: compound 1; then compounds 3, 2 and 4 (each within the scatter of the next).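

In this assay, for the compounds shown here, thiophen-2-yl in place of 4-chlorophenyl on the aromatic carbon ortho to a cyano group gives a 1.1-fold higher number from compound 3 to compound 4 (0.04 log units; within the scatter) and so offers the first direct comparison at this position. The two compounds read alike, so this carbon carries either aromatic ring with no difference that this assay can resolve. Nothing measured here explains that likeness.

Going by these compounds, whether an amine or a short alkyl chain on this carbon would read apart from these two rings remains open.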